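The source may hold more compounds than are shown below. What is called first, only, known or untested is meant among the compounds shown, and "the series" means these compounds.

Measured in a functional assay on HeLa cells (Homo sapiens) for antiproliferative activity, read by MTT assay, with a stated time of 48 h; on this read-out higher numbers stand for weaker inhibition and lower numbers for stronger inhibition:
- compound 1 `Cn1cc(-c2cnc3ccnc(N)c3c2)cn1` gives 40800 nM
- compound 2 `CC(=O)Nc1nccc2ncc(-c3cnn(C)c3)cc12` gives only a limit of the assay, > 50000 nM
- compound 3 `Cn1cc(-c2cnc3ccnc(NC(=O)C4CC4)c3c2)cn1` gives only a limit of the assay, > 50000 nM

Compound 3 stands at the limit of this assay; its actual number is not known, and it shares this position with compound 2 (the limit of > 50000 nM in this assay, at which 2 of the 3 values shown sit). The step from the unsubstituted amine to the cyclopropylcarbonyl amide, an at least 1.2-fold higher number from compound 1 to compound 3 (0.08 log units; that floor lies within the scatter), is therefore only a floor, and the floor itself lies within the scatter. The step between the two amides, a step that the two limits leave unreadable from compound 2 to compound 3, is left unreadable by the two limits.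

Compound 4 `Cn1cc(-c2cnc3ccnc(NC(=O)c4ccc(F)cc4)c3c2)cn1` differs from compound 3 by 4-fluorophenyl in place of cyclopropyl on a carbonyl carbon. Within the data shown here, the only measured steps that bear on this change are the two acylations of the ring nitrogen, and both brought the value to the limit (the limit of > 50000 nM in this assay, at which 2 of the 3 values shown sit). Among the measured compounds shown here, no measured step speaks to the size of the acyl group. With the two amides so far both at the limit, no movement beyond the scatter is expected for compound 4, and the estimated step is a step that the limit leaves unreadable from compound 3 to compound 4. Compound 4 is expected to give about 60000 nM in this assay, in a range from 20000 nM to 200000 nM, most likely again reported only as a limit.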

Compound 4, half-maximal inhibitory concentration: > 50000 nM
Compound 4: no number, only a limit; the forecaster's own chance of this, stated with the estimate: 70%; the middle value does not contradict the limit.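

In this assay compound 4 gives only a limit, > 50000 nM. No step from compound 2 or compound 3 to compound 4 can be read, because all three amides sit at the same limit: the limit of > 50000 nM in this assay, at which 3 of the 4 values shown sit.

The compounds shown leave open the actual values of these amides and whether the acyl group has any effect on them.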